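The compounds below may be only part of what the source reports. "The series", "measured", "known", "first", "only" and "open" are said of these compounds alone.

Measured compounds:
compound 1, `O=C(CSc1nc(Nc2ccccc2)c2ccccc2n1)Nc1ccccc1Br`, 19800 nM in a functional assay on PC-3 cells (Homo sapiens) for inhibition, read by MTT assay, with a stated time of 72 h; on this read-out lower numbers stand for stronger inhibition and higher numbers for weaker inhibition
compound 2, `COc1cccc(NC(=O)CSc2nc(Nc3ccccc3)c3ccccc3n2)c1`, 11600 nM
compound 3, `C=CC(=O)Nc1cccc(NC(=O)CSc2nc(Nc3ccccc3Br)c3ccccc3n2)c1`, 17100 nM

On the numbers shown, compound 3 stands second highest of the three; its value lies within the scatter of compound 1 and within the scatter of compound 2, so no order among the three can be read.

Compound 4 is `C=CC(=O)Nc1cccc(NC(=O)CSc2nc(Nc3cccc(C)c3)c3ccccc3n2)c1`. It differs from compound 3 by 3-methylphenyl in place of 2-bromophenyl on a nitrogen on an aromatic ring. Within the data shown here, the only measured step that bears on it is a 1.7-fold lower number from compound 1 to compound 2 (0.23 log units; within the scatter), a swap of the 2-bromophenyl for a 3-methoxyphenyl group, though on the amide-type nitrogen rather than on the nitrogen on the aromatic ring. Among the measured compounds shown here, no step at the nitrogen on the aromatic ring itself has been measured. For the measured compounds named here, both the one measured step and the spread of all three values sit within the scatter, so no step beyond the scatter is expected for compound 4 in this assay.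

The estimate for compound 4 is 15000 nM, in the range 6000 nM to 40000 nM, which corresponds to an expected step of a 1.1-fold lower number from compound 3 to compound 4 (0.06 log units; within the scatter).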

Compound 4, half-maximal inhibitory concentration: 29200 nM
For compound 4 the middle estimate is 1.9-fold (0.29 log units) below the measured one, within the range that was stated.
By their numbers in this assay, from the lowest: compounds 2, 3, 1 and 4 (each within the scatter of the next, the first and the last beyond it).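

In this assay the nitrogen on an aromatic ring now has its own measured step: 3-methylphenyl in place of 2-bromophenyl gives a 1.7-fold higher number from compound 3 to compound 4 (0.23 log units; within the scatter) and so stays inside the usual variation between repeats. Among these compounds, the earlier compounds offered a step only on the amide-type nitrogen, so this is the first reading at this position, and this exchange of two groups with the same heavy-atom count does not separate compound 3 from compound 4 on this read-out. No evidence bearing on this result is available.

Open, going by these compounds, is whether a different kind of group on this nitrogen, such as a phenyl carrying a carboxylic acid or an amine, or a longer alkyl chain, would give a step beyond the scatter. Also open, on these data alone, is whether a step at this nitrogen would read the same on other members.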